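Series notes: growth inhibition sitting at the assay limit

The source may hold more compounds than are shown below. What is called first, only, known or untested is meant among the compounds shown, and "the series" means these compounds.

Measured compounds:
- Compound 1 `Cn1cccc1-c1cc(-c2cccs2)nc(N)c1C#N`. In a functional assay on MCF7 cells (Homo sapiens) for inhibition, read by sulforhodamine B assay, with a stated time of 48 h (on this read-out higher numbers stand for weaker inhibition of growth and lower numbers for stronger inhibition of growth), compound 1 gives > 100000 nM, which is a limit of the assay and not a number.
- Compound 2 `Cn1cccc1-c1cc(-c2cccs2)[nH]c(=O)c1C#N`. In this assay compound 2 gives > 100000 nM, again a limit.
- Compound 3 `Cn1cccc1-c1cc(-c2ccccc2)[nH]c(=O)c1C#N`. In this assay compound 3 gives > 100000 nM, also a limit.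

Compound 2 and compound 3 differ in one place: phenyl in place of thiophen-2-yl on an aromatic carbon. The resulting step, a step that the two limits leave unreadable from compound 2 to compound 3, cannot be read in size, since both values are limits. Compound 1 and compound 2 differ in more than one place; the difference between the two cores is not broken down here.

Compound 4 `Cn1cccc1-c1cc(-c2ccccc2)nc(N)c1C#N` is not yet measured. It differs from compound 1 by phenyl in place of thiophen-2-yl on an aromatic carbon. The surroundings of the place are not identical to those in the pair of compound 2 and compound 3: in compound 1 the place is meta to an amino group (1 heavy atom), whereas in compound 2 it is meta to a group of 1 heavy atom. The change is therefore the same kind of change, not the same change.

What is known rests on (the limit of > 100000 nM in this assay, at which 3 of the 3 values shown sit). Within the data shown here, all three measured values sit at that limit, so no measured step gives a direction to carry over. Given that compound 1 gives > 100000 nM and that the same kind of change from compound 2 to compound 3 stayed at the limit, compound 4 is expected to remain there as well, the expected step being a step that the limit leaves unreadable from compound 1 to compound 4. The estimate for compound 4 is 200000 nM, with an expected range from 60000 nM to 1000000 nM, and most likely the assay will again report only a limit.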

Compound 4, concentration for 50% growth inhibition: > 100000 nM
Compound 4: a limit, no number; the forecaster's own chance of this, stated with the estimate: 90%; the middle value is on the limit's open side.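

In this assay compound 4 gives > 100000 nM as a limit of the assay and not a number. Among these compounds, with compound 1 also at a limit, the pair of compound 1 and compound 4 gives no step that can be read. The compounds shown leave open whether any change to the shared core brings growth inhibition to a readable value, and all that stands is one limit: the limit of > 100000 nM in this assay, at which 4 of the 4 values shown sit.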